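Anilinopyrimidines: methoxy for bromo on the aryl ring

The source may report more compounds than this note shows. Statements on the series, on what has been measured and on what is new or still open speak of the compounds shown alone.

Measured compounds and values:
compound 1, `COc1ccc(-c2ccnc(Nc3ccc(Cl)cc3Cl)n2)cc1`, 190 nM
compound 2, `CC(C)c1ccccc1Nc1nccc(-c2ccc(Br)cc2)n1`, 7030 nM
compound 3, `COc1cccc(Nc2nccc(-c3ccc(Br)cc3)n2)c1`, 148000 nM

In a functional assay on HepG2 cells (Homo sapiens) for antiproliferative activity, read by MTT assay (on this read-out lower numbers stand for stronger inhibition and higher numbers for weaker inhibition), compound 3 gives the highest number of the three; the nearest is compound 2, a gap beyond the scatter, and the furthest is compound 1. Compound 4, `COc1ccc(-c2ccnc(Nc3cccc(OC)c3)n2)cc1`, differs from compound 3 by methoxy in place of bromo on an aromatic carbon, at the place para to a large group. Among the compounds with values here, no pair of measured compounds isolates this change, so its size is unknown from the data; a step toward a lower number in this assay is expected, of modest size, because compound 1, which carries the methoxy, gives 190 nM while its other ring is not the same. The expected step is a 3.0-fold lower number from compound 3 to compound 4 (0.47 log units; beyond the scatter). Compound 4 is estimated at 50000 nM, within 10000 nM to 200000 nM.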

Compound 4, half-maximal inhibitory concentration: 13900 nM
Compound 4: middle estimate off by 3.6-fold (0.56 log units), on the high side; low and high end bracket the measured number.
By their numbers in this assay, from the lowest: compound 1; then compounds 2 and 4 (each within the scatter of the next); then compound 3.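

In this assay, methoxy in place of bromo on an aromatic carbon, para to a large group, gives an 11-fold lower number from compound 3 to compound 4 (1.03 log units; beyond the scatter). Within the data shown here, this is the first reading of a single change, as the earlier compounds differed from each other in more than one place, and it shows that the number responds strongly to the group at this position. Nothing at hand accounts for the size of the step.

As far as these compounds go, whether an amine or a carboxylic acid at this position would lower the number further remains open. So does whether the same step would appear with the other ring of compound 1 or compound 2.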